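Methyl on the Ring Amide Nitrogen in Two Core Series

The compounds below may be only part of what the source reports. "The series", "measured", "known", "first", "only" and "open" are said of these compounds alone.

Measured compounds:
compound 1, `O=C1CN(C2CCCC2)c2nc(Nc3ccc(N4CCCCC4)cc3)ncc2N1`, gives 25000 nM in a functional assay on MDA-MB-231 cells (Homo sapiens) for inhibition, read by MTT assay, with a stated time of 48 h; a higher number here means a weaker inhibitor, a lower number a stronger inhibitor.
compound 2, `CN1CCN(c2ccc(Nc3ncc4c(n3)N(C3CCCC3)CC(=O)N4)nc2)CC1`, gives > 30000 nM in this assay.
compound 3, `CN1C(=O)CN(C2CCCC2)c2nc(Nc3ccc(N4CCCCC4)cc3)ncc21`, gives 21200 nM in this assay.

Compound 1 and compound 3 share a core and differ in one place, (methyl in place of hydrogen on an amide-type nitrogen in a ring). The step this change made is a 1.2-fold lower number from compound 1 to compound 3 (0.07 log units; within the scatter), so the methyl left the inhibition essentially unchanged in this pair.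

The value for compound 2 is a limit of the assay and not a number; it sits at the limit of > 30000 nM in this assay, at which 1 of the 3 values shown sits. How the core of compound 2 differs from the core of compound 1 is not broken down here.

Compound 4, `CN1CCN(c2ccc(Nc3ncc4c(n3)N(C3CCCC3)CC(=O)N4C)nc2)CC1`, has not yet been measured. It stands to compound 2 as compound 3 stands to compound 1: methyl in place of hydrogen on an amide-type nitrogen in a ring. The place of the change is described in the same words in both pairs, so it is the same change.

For compound 4 the expected step is a step that the limit leaves unreadable from compound 2 to compound 4, a flat step, resting on the measured pair in which a 1.2-fold lower number from compound 1 to compound 3 (0.07 log units; within the scatter). Since compound 2 gives only a limit, the expectation is that compound 4 is also weak. Compound 4 is expected to give about 35000 nM, with a likely range from 18000 nM to 80000 nM, and there is a high chance that the assay again reports only a limit.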

Compound 4, half-maximal inhibitory concentration: 23700 nM
Estimate against measurement, compound 4: 1.5-fold (0.17 log units) above; measured number inside the range.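

The value of compound 2, > 30000 nM, is a limit of the assay and not a number. Methyl in place of hydrogen on an amide-type nitrogen in a ring gives an at least 1.2-fold lower number from compound 2 to compound 4 (0.10 log units; that floor lies within the scatter) in this assay, so the step on this core is known only as a floor, and its full size stays unknown. Set beside the earlier pair, the result fits a change that carries over from one core to the other with little effect on the number, but it does not show that the step has the same size on both cores, and two pairs make no rule for the series: the same change on two cores in this assay, a 1.2-fold lower number (0.07 log units; within the scatter) from compound 1 to compound 3 and an at least 1.2-fold lower number (0.10 log units; that floor lies within the scatter) from compound 2 to compound 4; the limit leaves it open whether they differ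

The compounds shown leave open whether a larger group on that amide-type nitrogen, such as an ethyl group or a longer chain ending in an amine or a carboxylic acid, would move the number beyond the usual scatter. They also leave open whether the methyl would behave in the same way on a core that carries a cyclohexyl or isopropyl group in place of the cyclopentyl group.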